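Three Hydroxyphenyl Arms: Moving One Hydroxyl Position

The source may hold more compounds than are shown below. What is called first, only, known or untested is meant among the compounds shown, and "the series" means these compounds.

Compound 1 `Oc1cccc(-c2cc(-c3ccccc3O)cc(-c3cccc(O)c3)n2)c1` gives 4570 nM in a functional assay on T47D cells (Homo sapiens) for cytotoxicity, read by CCK-8 assay, with a stated time of 4 days; a higher number here means a weaker inhibitor, a lower number a stronger inhibitor.
Compound 2 `Oc1ccc(-c2cc(-c3cccc(O)c3)cc(-c3cccc(O)c3)n2)cc1` gives 3920 nM in this assay.

Compound 2 stands beside compound 1, the gap between the two values lying within the usual scatter, so neither compound can be called the stronger inhibitor. Compound 3 `Oc1cccc(-c2cc(-c3cccc(O)c3)nc(-c3cccc(O)c3)c2)c1` differs from compound 2 in this way: 3-hydroxyphenyl in place of 4-hydroxyphenyl on an aromatic carbon. Among the compounds with values here, no measured pair shows such a change, so only the two values above guide the expectation, and both point to the same region. Compound 3 is expected to land close to compound 2, the step of a 1.1-fold higher number from compound 2 to compound 3 (0.06 log units; within the scatter) no larger than the scatter. The estimate for compound 3 is 4500 nM, within 1500 nM to 13000 nM.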

Compound 3, half-maximal inhibitory concentration: 2050 nM
For compound 3 the middle estimate is 2.2-fold (0.34 log units) above the measured one; measured number inside the range.
By their numbers in this assay, from the lowest: compounds 3, 2 and 1 (each within the scatter of the next, the first and the last beyond it).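

In this assay, 3-hydroxyphenyl in place of 4-hydroxyphenyl, on the aromatic carbon next to the ring nitrogen, gives a 1.9-fold lower number from compound 2 to compound 3 (0.28 log units; within the scatter), so these two groups cannot be told apart at this position. 3-hydroxyphenyl in place of 2-hydroxyphenyl gives a 2.2-fold lower number from compound 1 to compound 3 (0.35 log units; beyond the scatter), a modest step and the only one here beyond the scatter.

As far as these compounds go, whether an amine or a carboxylic acid in place of a hydroxyl would shift the number remains open. Nothing given here accounts for either step.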